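The compounds below may be only part of what the source reports. "The series", "measured", "known", "first", "only" and "open" are said of these compounds alone.

Of the compounds shown here, three have been measured in an assay on HEK293 cells for binding affinity to 5-hydroxytryptamine receptor 7 (Homo sapiens), read by radioligand binding, tested at 1 uM; on this read-out lower numbers stand for less inhibition and higher numbers for more inhibition at the one concentration tested (going by the name of the read-out). Compound 1 `Brc1cccc2ccn(CCN3CCN4CCCCC4C3)c12` gives 13%. Compound 2 `CN1CCCN(CCn2ccc3cc(Br)ccc32)CC1` gives 65%. Compound 3 `CN1CCCN(CCn2ccc3ccc(Cl)cc32)CC1` gives 85%, the highest of the three numbers: compound 2 lies nearest to it, with a gap beyond the scatter, and compound 1 lies furthest, with a gap also beyond the scatter. None of these three pairs differs in only one place, so the numbers show rank and nothing more.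

Compound 4 `C=Cc1ccc2ccn(CCN3CCCN(C)CC3)c2c1` has not yet been measured in this assay. It differs from compound 3 in one place: vinyl in place of chloro on an aromatic carbon. Vinyl in place of chloro on an aromatic carbon is a change for which no measured pair in this set gives guidance. Starting from the high number of compound 3, the expected step is a number 15 percentage points lower from compound 3 to compound 4 (beyond the scatter) in this assay, a modest fall that may still sit close to the scatter. On that basis compound 4 is expected to give 70%, with a range from 45% to 90%.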

Compound 4, a percentage reported as inhibition, at one concentration (the size of the read-out at that concentration, not a potency): 79%
Beside the measured number, compound 4's estimate is 9 percentage points below it, within the range that was stated.
By their numbers in this assay, from the lowest: compound 1; then compound 2; then compounds 4 and 3 (each within the scatter of the next).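

Going by these compounds alone, this is the first pair that differs in one place, so it gives the first direct reading of a change on the core. In this assay, vinyl in place of chloro on this aromatic carbon, meta to a fused ring and para to a fused ring, gives a number 6 percentage points lower from compound 3 to compound 4 (within the scatter), so a group of two carbon atoms with a double bond and a single chlorine atom cannot be told apart here, and neither compound can be placed above the other. Nothing measured on these compounds explains this result.

What the compounds shown leave open is whether this position would accept groups of a different kind, such as an amine, a carboxylic acid or a longer chain. They also leave open whether vinyl and chloro would match in the same way on another aromatic carbon of the core.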